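The compounds below may be only part of what the source reports. "The series", "measured", "known", "first", "only" and "open" are said of these compounds alone.

Compound 1 `O=C(Nc1ccccc1C(F)(F)F)c1ccc2ccccc2n1`, compound 2 `O=C(Nc1cc(C(F)(F)F)cc(C(F)(F)F)c1)C1CCc2ccccc2N1C(=O)c1ccc(Cl)cc1`, compound 3 `COc1ccc(NC(=O)c2ccc3ccccc3n2)cc1`.

In a functional assay on NCI-H23 cells (Homo sapiens) for cytotoxicity, read by sulforhodamine B assay, with a stated time of 72 h (on this read-out higher numbers stand for weaker inhibition of growth and lower numbers for stronger inhibition of growth), compound 1 gives only a limit, > 90000 nM, not a number. Compound 2 gives 889 nM, and compound 3 gives 7650 nM. Of the two numbers, compound 2 has the lower one, and its gap to compound 3 lies beyond the usual scatter. Compound 4 `CC(=O)N1c2ccccc2CCC1C(=O)Nc1cc(C(F)(F)F)cc(C(F)(F)F)c1` has not yet been measured in this assay. It differs from compound 2 in one place: methyl in place of 4-chlorophenyl on a carbonyl carbon. Among the measured compounds shown here, no pair of measured compounds differs by this change alone, so its effect has not been seen directly. The group that leaves is far larger than the one that enters, and the step of a 5.6-fold higher number from compound 2 to compound 4 (0.75 log units; beyond the scatter) is expected to be a weakening beyond the scatter. Compound 4 is estimated at 5000 nM, within the range 1500 nM to 20000 nM.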

Compound 4, concentration for 50% growth inhibition: > 70000 nM
Compound 4: only a limit was reported (the forecaster's own chance of this, stated with the estimate: 5%); middle value at least 14-fold (1.14 log units) from the limit.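

Replacing 4-chlorophenyl with methyl on this carbonyl carbon gives an at least 78-fold higher number from compound 2 to compound 4 (1.89 log units; beyond the scatter) in this assay, the first direct view of this change. On this core, then, growth inhibition depends heavily on the group at this position. The step is a minimum and not an exact size, and compound 4 gives only a limit: the limit of > 70000 nM in this assay, at which 1 of the 4 values shown sits.

From the compounds shown here alone, whether the ring itself or its chlorine matters more remains open. So does whether an unsubstituted phenyl or a benzyl group on this carbonyl carbon would keep growth inhibition.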